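The source may report more compounds than this note shows. Statements on the series, on what has been measured and on what is new or still open speak of the compounds shown alone.

Measured so far:
- compound 1, `CC(=O)N1CC2CC(C1)N2`: in an assay on SH-EP1 cells for displacement of a labelled ligand from Neuronal acetylcholine receptor; alpha4/beta2 (Homo sapiens), read by scintillation counting (on this read-out lower numbers stand for stronger inhibition and higher numbers for weaker inhibition), compound 1 gives 150 nM
- compound 2, `CC(C)C(=O)N1CC2CC(C1)N2`: in this assay compound 2 gives 130 nM

Both compounds share the same core, a bicyclic amine carrying an amide group, and differ only in the group attached to the carbonyl carbon. The step of a 1.2-fold lower number from compound 1 to compound 2 (0.06 log units; within the scatter) is within the usual scatter, so the two numbers cannot be told apart; compound 2 and compound 1 stand together, with no real gap between them.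

Compound 3, `C[C@@H]1C[C@H]1C(=O)N1CC2CC(C1)N2`, takes the change one stage further: 2-methylcyclopropyl in place of isopropyl on a carbonyl carbon. Among the compounds with values here, the only measured step that bears on this position is a 1.2-fold lower number from compound 1 to compound 2 (0.06 log units; within the scatter), which showed that enlarging the group on the carbonyl carbon from methyl to isopropyl left the number essentially unchanged. On that basis a further enlargement to the 2-methylcyclopropyl group is expected to give no step beyond the scatter in this assay, in either direction. The number for compound 3 is therefore estimated at 110 nM, within a range from 40 nM to 350 nM, which corresponds to an expected step of a 1.2-fold lower number from compound 2 to compound 3 (0.07 log units; within the scatter).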

Compound 3, inhibition constant: 1 nM
For compound 3 the middle estimate is 110-fold (2.04 log units) above the measured one; measured number below the stated range.
By their numbers in this assay, from the lowest: compound 3; then compounds 2 and 1 (each within the scatter of the next).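

The group on the carbonyl carbon is not a position where changes make little difference: in this assay, the swap of methyl for isopropyl left the number within the scatter, yet 2-methylcyclopropyl gives a 130-fold lower number from compound 2 to compound 3 (2.11 log units; beyond the scatter) and, measured against the smallest group shown, a 150-fold lower number from compound 1 to compound 3 (2.18 log units; beyond the scatter). The large step comes with a small structural change, from 3 heavy atoms to 4, with a three-membered ring and 2 defined stereocentres entering and no hydrogen-bond donor, acceptor or net charge added, so the number here does not simply follow the size of the group across these three compounds. Nothing available explains why this group gives so much lower a number than isopropyl.

The compounds shown cannot separate the contributions of the ring, its methyl and the stereocentres; plain cyclopropyl and the other stereoisomers of 2-methylcyclopropyl on the same carbonyl carbon would bear directly on that. Going by these compounds, how the number responds to other groups there, such as a cyclobutyl ring, a phenyl ring or an amine, also remains open.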